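The compounds below may be only part of what the source reports. "The series", "measured", "known", "first", "only" and "open" are said of these compounds alone.

Measured compounds:
- compound 1, `CC(C)OC(=O)N1CCC(Oc2ncnc3c2CCN3c2ccc(S(C)(=O)=O)c(F)c2)CC1`, gives 109% in a functional assay on CHO-K1 cells with Glucose-dependent insulinotropic receptor (Homo sapiens) as the target, read by a luciferase reporter, with a stated time of 5 h; a lower number here means a smaller maximal response, a higher number a larger maximal response
- compound 2, `CSc1ccc(N2CCc3c(OC4CCN(C(=O)OC(C)C)CC4)ncnc32)cc1F`, gives 121% in this assay

Among the measured compounds shown here, compound 2 stands highest of the two numbers measured so far; its nearest neighbour is compound 1, and the step of a number 12 percentage points higher from compound 1 to compound 2 (beyond the scatter) lies beyond the usual scatter, though it is modest. The two compounds differ in one group only on the aromatic ring: methylsulfanyl in compound 2 in place of methylsulfonyl in compound 1.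

Compound 3, `CC(C)OC(=O)N1CCC(Oc2ncnc3c2CCN3c2ccc([S@+](C)[O-])c(F)c2)CC1`, has not yet been measured. It differs from compound 2 by a group of 3 heavy atoms (1 carbon, 1 oxygen, 1 sulfur; no ring) in place of a group of 2 heavy atoms (1 carbon, 1 sulfur; no ring), on an aromatic carbon. The entering group stands between methylsulfonyl and methylsulfanyl in its make-up, so compound 3 sits between the two measured compounds. For the measured compounds named here, the only step that bears on it is a number 12 percentage points higher from compound 1 to compound 2 (beyond the scatter), which was modest. A step no larger than that is therefore expected in this assay, most likely downward from compound 2 toward the number of compound 1, or none beyond the scatter. For compound 3 the estimate is 115%, within the range 95% to 135%, which means an expected step of a number 6 percentage points lower from compound 2 to compound 3 (within the scatter).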

Compound 3, largest response reached (reported as percent of maximum), in percent of the reference or control that the assay uses: 122%
Compound 3: the middle estimate sits 7 percentage points below what was measured, within the range that was stated.
By their numbers in this assay, from the lowest: compound 1; then compounds 2 and 3 (each within the scatter of the next).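

The step of a number 1 percentage points higher from compound 2 to compound 3 (within the scatter) shows that, in this assay, methylsulfanyl on this aromatic carbon can give way to the group of 3 heavy atoms (1 carbon, 1 oxygen, 1 sulfur) with no change that stands out from the scatter. The step of a number 13 percentage points higher from compound 1 to compound 3 (beyond the scatter) then shows that this same group stands clear of methylsulfonyl, so among these three compounds the maximal response does not rise in even stages as oxygen leaves the sulfur: compound 2 and compound 3 lie level, and only compound 1 sits apart. Nothing measured alongside these numbers bears on the reason for this pattern.

The compounds shown leave open how a group without sulfur at this position, such as a nitrile or a carboxylic acid, would compare with these three. Also open, going by these compounds, is whether the defined stereocentre of the entering group matters, a question that would need the opposite arrangement at the sulfur for comparison.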